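From propylamino to ethyl(methyl)amino on a shared core

The compounds below may be only part of what the source reports. "The series", "measured", "known", "first", "only" and "open" are said of these compounds alone.

Among the measured compounds shown here, in a functional assay on the whole organism with Rattus norvegicus as the target (on this read-out higher numbers stand for an effect only at larger amounts of compound and lower numbers for an effect already at smaller amounts), compound 1 (`CCOC(=O)C(=O)Nc1cccc(N)c1C#N`) gives 0.05 mg/kg and compound 2 (`CCCNc1cccc(NC(=O)C(=O)OCC)c1C#N`) gives 0.5 mg/kg, so compound 2 holds the higher of the two numbers measured so far. Compound 3 (`CCOC(=O)C(=O)Nc1cccc(N(C)CC)c1C#N`) has the same atoms as compound 2 but joined differently, and the change is ethyl(methyl)amino in place of propylamino on an aromatic carbon on the shared core. For the measured compounds named here, only one measured step bears on this change. It is a 10-fold higher number from compound 1 to compound 2 (1.00 log units; beyond the scatter), where propyl took the place of a hydrogen on the same nitrogen and the number rose. Going by the values given here, no measured compound has that nitrogen substituted as in compound 3, so this evidence is thin and the direction is only a tentative expectation. Resting on a 10-fold higher number from compound 1 to compound 2 (1.00 log units; beyond the scatter), a further rise of smaller size is expected in this assay. The expected step is a 2.0-fold higher number from compound 2 to compound 3 (0.30 log units; within the scatter) by this estimate. For compound 3 the estimated value is 1 mg/kg in this assay, with an expected range from 0.2 mg/kg to 5 mg/kg for repeated measurements.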

Compound 3, dose for half-maximal effect: 0.3 mg/kg
For compound 3 the middle estimate is 3.3-fold (0.52 log units) above the measured one; the measured number falls inside the stated range.
By their numbers in this assay, from the lowest: compound 1; then compounds 3 and 2 (each within the scatter of the next).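

Within this assay the exchange of propylamino for ethyl(methyl)amino, two groups with the same count of heavy atoms, gives a 1.7-fold lower number from compound 2 to compound 3 (0.22 log units; within the scatter) even though the group that enters has no hydrogen-bond donor while the group that leaves has one. Compound 3 also keeps its distance from compound 1: a 6.0-fold higher number from compound 1 to compound 3 (0.78 log units; beyond the scatter) runs in the same direction as a 10-fold higher number from compound 1 to compound 2 (1.00 log units; beyond the scatter) and lies beyond the scatter, so among these compounds the higher number goes with a substituted nitrogen, whether or not a hydrogen remains on it. Nothing in the data shown explains these numbers.

On these data alone, it stays open how far this holds for other groups on the same aromatic carbon, such as the shorter dimethylamino or the longer butylamino, and whether the number would then stay level or move further from that of compound 1. Also open, as far as these compounds go, is how a carboxylic acid in place of the ethyl ester would read out, as all three compounds carry that ester.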